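Replacing thiophen-2-yl with 2-methoxyphenyl in compound 1

The source may report more compounds than this note shows. Statements on the series, on what has been measured and on what is new or still open speak of the compounds shown alone.

Compound 1 `COc1cc(/C=C/C(=O)/C=C/c2cccs2)ccc1OCc1cn(CCOc2cc(=O)oc3ccccc23)nn1` gives 11400 nM in a functional assay on COLO 205 cells (Homo sapiens) for cytotoxicity, read by sulforhodamine B assay, with a stated time of 48 h (on this read-out higher numbers stand for weaker inhibition and lower numbers for stronger inhibition), and lies within the usual scatter of both of its measured relatives. Compound 2 `COc1cccc(/C=C/C(=O)/C=C/c2ccc(OCc3cn(CCOc4cc(=O)oc5ccccc45)nn3)c(OC)c2)c1` gives 11900 nM in this assay and compound 3 `COc1ccc(/C=C/C(=O)/C=C/c2ccc(OCc3cn(CCCOc4cc(=O)oc5ccccc45)nn3)c(OC)c2)cc1OC` gives 13000 nM on the same scale, so these numbers do not rank compound 1 against them. Compound 4 `COc1ccccc1/C=C/C(=O)/C=C/c1ccc(OCc2cn(CCOc3cc(=O)oc4ccccc34)nn2)c(OC)c1` has not yet been measured. It differs from compound 1 by a single exchange, 2-methoxyphenyl in place of thiophen-2-yl on a double-bonded chain carbon bound to a double-bonded chain carbon and this exchange sits on a double-bonded chain carbon bound to a double-bonded chain carbon. The closest evidence is the step of a 1.0-fold higher number from compound 1 to compound 2 (0.02 log units; within the scatter) in which 3-methoxyphenyl takes the place of thiophen-2-yl at that same spot. For the measured compounds named here, no measured compound carries 2-methoxyphenyl there, so this comparison is only a guide. With that single step as a guide, the expected step is a 1.1-fold higher number from compound 1 to compound 4 (0.02 log units; within the scatter) and thus no change beyond the scatter is expected. Compound 4 is estimated at 12000 nM with an expected range of 6500 nM to 22000 nM on this read-out.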

Compound 4, half-maximal inhibitory concentration: 11500 nM
The estimate for compound 4 lay 1.0-fold (0.02 log units) above the measured number; the measured number falls inside the stated range.
By their numbers in this assay, from the lowest: compounds 1, 4, 2 and 3 (each within the scatter of the next).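

In this assay, this spot on a double-bonded chain carbon bound to a double-bonded chain carbon now has a third group to compare: 2-methoxyphenyl in place of thiophen-2-yl gives a 1.0-fold higher number from compound 1 to compound 4 (0.00 log units; within the scatter), and 2-methoxyphenyl in place of 3-methoxyphenyl gives a 1.0-fold lower number from compound 2 to compound 4 (0.01 log units; within the scatter). Both steps stay within the scatter, so thiophen-2-yl, 3-methoxyphenyl and 2-methoxyphenyl cannot be told apart here, even though 2-methoxyphenyl has 8 heavy atoms against the 5 of thiophen-2-yl. Nothing available explains why these groups read alike.

Going by these compounds, whether a carboxylic acid or an amine at this spot would move the number beyond the scatter remains open. So does whether these three groups would also read alike on other cell lines.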